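A few compounds are considered here, and "the series" means these few. Any claim that something is new, unique, unknown or untested is made for them only; others in the source may bear on it.

Compound 1 `C=CC(=O)NCC#Cc1ccc2ncn(-c3ccnc(N)n3)c2c1` gives 6310 nM in an assay on Sf9 cells for inhibition of mitogen-activated protein kinase kinase kinase 14 variant S549D (Homo sapiens), with a stated time of 30 min, in the presence of a further agent that is not named here; a lower number here means a stronger inhibitor, a higher number a weaker inhibitor.
Compound 2 `C=Cc1ccnc(C#Cc2ccc3ncn(-c4ccnc(N)n4)c3c2)n1` gives 1580 nM.
Compound 3 `C#Cc1nccc(C#Cc2ccc3ncn(-c4ccnc(N)n4)c3c2)n1` gives 39800 nM.

Compound 1 stands second highest of these three numbers: the step of a 4.0-fold lower number from compound 1 to compound 2 (0.60 log units; beyond the scatter) is modest and beyond the scatter, while the step of a 6.3-fold higher number from compound 1 to compound 3 (0.80 log units; beyond the scatter) runs the other way. Compound 4 `C=Cc1ccc(C#Cc2ccc3ncn(-c4ccnc(N)n4)c3c2)cn1` differs from compound 1 in one place: 6-vinylpyridin-3-yl in place of ((vinylcarbonyl)amino)methyl on a triple-bonded carbon. The step of a 4.0-fold lower number from compound 1 to compound 2 (0.60 log units; beyond the scatter) bears most directly on this change, since there too a vinyl-bearing six-membered aromatic ring replaces the ((vinylcarbonyl)amino)methyl group. The step of a 25-fold higher number from compound 2 to compound 3 (1.40 log units; beyond the scatter) shows that what the ring carries matters greatly. A modest move toward a lower number is therefore expected, estimated as a 2.5-fold lower number from compound 1 to compound 4 (0.40 log units; beyond the scatter). Compound 4 is expected to give about 2500 nM, in the range 800 nM to 8000 nM.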

Compound 4, half-maximal inhibitory concentration: 79400 nM
For compound 4 the middle estimate is 32-fold (1.50 log units) below the measured one; the measured number lies above the stated range.
By their numbers in this assay, from the lowest: compound 2; then compound 1; then compounds 3 and 4 (each within the scatter of the next).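

A vinyl-bearing six-membered aromatic ring on the triple-bonded carbon is therefore no general gain over ((vinylcarbonyl)amino)methyl: 6-vinylpyridin-3-yl gives a 13-fold higher number from compound 1 to compound 4 (1.10 log units; beyond the scatter). The ring itself decides the outcome, as both rings carry vinyl yet the change shows a 50-fold higher number from compound 2 to compound 4 (1.70 log units; beyond the scatter), while a 2.0-fold higher number from compound 3 to compound 4 (0.30 log units; within the scatter) leaves those two compounds unseparated. No measured evidence here explains these differences. From the compounds shown here alone, it remains open how much of the result of compound 2 depends on its vinyl group. A ring carrying an amine or a carboxylic acid in place of vinyl would test this.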